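A few compounds are considered here, and "the series" means these few. Any claim that something is new, unique, unknown or untested is made for them only; others in the source may bear on it.

Compound 1 `O=C(Nc1ccc(Oc2ccnc3[nH]ccc23)cc1)c1cc2cccnc2n(-c2ccc(Br)cc2F)c1=O` is the reference point of this small set. In a functional assay on A549 cells (Homo sapiens) for antiproliferative activity, read by MTT assay, with a stated time of 72 h (on this read-out lower numbers stand for stronger inhibition and higher numbers for weaker inhibition), compound 1 gives 1570 nM. Compound 2 `O=C(Nc1ccc(Oc2ccnc3[nH]ccc23)cc1)c1cc2cccnc2n(-c2ccc(C(F)(F)F)cc2Cl)c1=O` carries a different aryl group on the ring nitrogen, namely (2-chloro-4-(trifluoromethyl)phenyl in place of 4-bromo-2-fluorophenyl on an aromatic nitrogen), and in this assay compound 2 gives 3230 nM, which amounts to a 2.1-fold higher number from compound 1 to compound 2 (0.31 log units; beyond the scatter). Compound 3 `O=C(Nc1ccc(Oc2ccnc3[nH]ccc23)c(F)c1)c1cc2cccnc2n(-c2ccc(Br)cc2F)c1=O` differs from compound 1 in its core only by fluoro in place of hydrogen on an aromatic carbon; in this assay compound 3 gives 460 nM, so that a 3.4-fold lower number from compound 1 to compound 3 (0.53 log units; beyond the scatter), and it holds the lowest number of the three measured compounds.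

Compound 4 `O=C(Nc1ccc(Oc2ccnc3[nH]ccc23)c(F)c1)c1cc2cccnc2n(-c2ccc(C(F)(F)F)cc2Cl)c1=O` has not yet been measured. It stands to compound 3 as compound 2 stands to compound 1: the change is 2-chloro-4-(trifluoromethyl)phenyl in place of 4-bromo-2-fluorophenyl on an aromatic nitrogen, made at a place described in exactly the same words as for the earlier pair, so it is the same change on a fluorinated core. Because a 2.1-fold higher number from compound 1 to compound 2 (0.31 log units; beyond the scatter) was observed for that change, a step of similar size is expected here, namely a 2.2-fold higher number from compound 3 to compound 4 (0.34 log units; beyond the scatter). Compound 4 is therefore estimated to give 1000 nM in this assay, plausibly between 450 nM and 2300 nM.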

Compound 4, half-maximal inhibitory concentration: 1020 nM
Compound 4: the middle estimate sits 1.0-fold (0.01 log units) below what was measured; low and high end bracket the measured number.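

In this assay, the exchange of 4-bromo-2-fluorophenyl for 2-chloro-4-(trifluoromethyl)phenyl on the aromatic nitrogen gives a 2.2-fold higher number from compound 3 to compound 4 (0.35 log units; beyond the scatter), and the step keeps its size when carried to the fluorinated core: the same change on two cores in this assay, a 2.1-fold higher number (0.31 log units; beyond the scatter) from compound 1 to compound 2 and a 2.2-fold higher number (0.35 log units; beyond the scatter) from compound 3 to compound 4, 1.1-fold (0.03 log units) apart, within the scatter of two such steps. Read the other way, fluoro in place of hydrogen on an aromatic carbon gives a 3.2-fold lower number from compound 2 to compound 4 (0.50 log units; beyond the scatter), and this step likewise holds with either aryl group in place: the same change on two cores in this assay, a 3.4-fold lower number (0.53 log units; beyond the scatter) from compound 1 to compound 3 and a 3.2-fold lower number (0.50 log units; beyond the scatter) from compound 2 to compound 4, 1.1-fold (0.03 log units) apart, within the scatter of two such steps. Across these four compounds the two changes therefore act independently of each other, but this rests on a single square of compounds in one cell line and does not show that the aryl exchange would transfer to any other core, nor why either change moves the number.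

The compounds shown leave open what an amine or a carboxylic acid would do in place of the trifluoromethyl on the aryl group. They also leave open whether a chloro or a methyl group could stand in for the fluoro on the core with a similar step.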